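The compounds below may be only part of what the source reports. "The series", "measured", "known", "first", "only" and "open" are said of these compounds alone.

Measured so far:
- compound 1, `COc1ccc(-c2[nH]c3ccc(OC)cc3c2/C=C(\C#N)S(=O)(=O)c2ccccc2)cc1` — 1700 nM
- compound 2, `CC(=O)/C(=C\c1c(-c2ccccc2)[nH]c2ccccc12)S(=O)(=O)c1ccccc1` — 1300 nM

Both compounds were tested in a functional assay on NCI-H522 cells (Homo sapiens) for inhibition, read by sulforhodamine B assay, with a stated time of 48 h; on this read-out higher numbers stand for weaker inhibition of growth and lower numbers for stronger inhibition of growth. Compound 1 gives 1700 nM, and compound 2 gives 1300 nM. These two numbers sit within the usual scatter of each other, so compound 2 cannot be set apart from compound 1 on what this assay shows; the two simply stand side by side.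

Compound 3, `O=C(/C(=C\c1c(-c2ccccc2)[nH]c2ccccc12)S(=O)(=O)c1ccccc1)c1ccccc1`, has not been measured. It differs from compound 2 in one place: phenyl in place of methyl on a carbonyl carbon, or acetyl to benzoyl when the difference is cut one bond further out. For the measured compounds named here, no pair of measured compounds shows this change, so no step can be read off for it. With nothing in the measured pair to lean on, the expectation is for a step of no more than modest size in this assay, in either direction, and quite possibly none beyond the scatter. Compound 3 is therefore expected to give about 1000 nM in this assay, with a plausible range from 300 nM to 3500 nM, which amounts to an expected step of a 1.3-fold lower number from compound 2 to compound 3 (0.11 log units; within the scatter).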

Compound 3, concentration for 50% growth inhibition: 91800 nM
Compound 3: middle estimate off by 92-fold (1.96 log units), on the low side, and the stated range ends below it.
By their numbers in this assay, from the lowest: compounds 2 and 1 (each within the scatter of the next); then compound 3.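

In this assay the group on this carbonyl carbon proves able to change the read-out strongly: phenyl in place of methyl, or acetyl to benzoyl when cut one bond further out, gives a 71-fold higher number from compound 2 to compound 3 (1.85 log units; beyond the scatter) toward weaker inhibition of growth. The earlier compounds shown here could not show this, as compound 1 and compound 2 differ in more than one place and offered no step to read at this position. Nothing available speaks to what lies behind the size of this step.

The compounds shown leave open how other groups on this carbonyl carbon would behave in this assay, for instance an ethyl group, a longer chain, or an amine that would turn the ketone into an amide, and so whether the sharp change sets in only with phenyl. With a single step at this place, they also leave open whether the same change would have an effect of similar size on another core, such as that of compound 1.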